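From Furan-2-yl to Furan-3-yl at the Assay Limit

The source may hold more compounds than are shown below. What is called first, only, known or untested is meant among the compounds shown, and "the series" means these compounds.

In a functional assay on CEM-DNR-bulk cells (Homo sapiens), read by MTT assay, with a stated time of 72 h (a lower number here means a stronger inhibitor, a higher number a weaker inhibitor), compound 2 `CNc1ncnc2c1c(-c1ccco1)cn2[C@@H]1O[C@H](CO)[C@@H](O)[C@H]1O` gives > 20000 nM as a limit and not a number. Compound 1 `CSc1ncnc2c1c(-c1ccoc1)cn2[C@@H]1O[C@H](CO)[C@@H](O)[C@H]1O` gives > 20000 nM as a limit too. These two readings make up the limit of > 20000 nM in this assay, at which 2 of the 2 values shown sit, and so compound 2 has no exact place on the scale.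

Compound 3 `CNc1ncnc2c1c(-c1ccoc1)cn2[C@@H]1O[C@H](CO)[C@@H](O)[C@H]1O` differs from compound 2 in one place, with furan-3-yl in place of furan-2-yl on an aromatic carbon as the counted change. It has furan-3-yl in place of furan-2-yl on an aromatic carbon, the same atoms joined differently. For the measured compounds named here, no measured pair isolates this change. Compound 1 already carries furan-3-yl and reads > 20000 nM as a limit, so that group alone is not expected to bring a large gain. In this assay an estimated at least 1.1-fold lower number from compound 2 to compound 3 (0.04 log units; that floor lies within the scatter) is expected, with no step beyond the scatter. Compound 3 is expected at 18000 nM with an estimated range from 6000 nM to 20000 nM as its span.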

Compound 3, half-maximal inhibitory concentration: > 20000 nM
Compound 3 gave a limit, no number (the forecaster's own chance of this, stated with the estimate: 70%); at least 1.1-fold (0.04 log units) between middle value and limit.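

In this assay neither step to compound 3, from compound 2 or from compound 1, can be read, because all three compounds share one limit: the limit of > 20000 nM in this assay, at which 3 of the 3 values shown sit.

The compounds shown leave open whether furan-3-yl in place of furan-2-yl, or methylamino in place of methylsulfanyl, changes the reading at all.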